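The compounds below may be only part of what the source reports. "The series", "measured", "known", "first", "only" and "open" are said of these compounds alone.

Compound 1 `Cc1ncc(C)n2nc(-c3ccn4cc(-c5ccc(Br)cc5)nc4n3)nc12` gives 15 mL.min-1.g-1 in an ADME assay on microsomes from liver (Rattus norvegicus) for metabolic stability, read by LC-MS, in the presence of a further agent that is not named here; on this read-out higher numbers stand for fast clearance and lower numbers for slow clearance.
Compound 2 `Cc1ncc(C)n2nc(-c3ccc4nc(-c5ccccn5)[nH]c4c3)nc12` gives 11.1 mL.min-1.g-1 in this assay.
Compound 3 `COc1cccnc1-c1nc2ccc(-c3nc4c(C)ncc(C)n4n3)cc2[nH]1` gives 5.4 mL.min-1.g-1 in this assay.

Among these three, compound 1 carries the highest number; compound 2 lies within the scatter of compound 1, whereas compound 3 sits beyond it. Within the data shown here, the only step measured in this set is a 2.1-fold lower number from compound 2 to compound 3 (0.31 log units; beyond the scatter), which concerns a methoxy on a different part of the molecule and does not touch the bromophenyl group. Compound 4 `Cc1ncc(C)n2nc(-c3ccn4cc(-c5ccccc5Br)nc4n3)nc12` differs from compound 1 by 2-bromophenyl in place of 4-bromophenyl on an aromatic carbon. Among the measured compounds shown here, no measured step bears directly on moving the bromine around the ring, so no change beyond the scatter is expected. Compound 4 is therefore estimated at 15 mL.min-1.g-1, with a range of 7 mL.min-1.g-1 to 32 mL.min-1.g-1. That estimate amounts to no change at the digits printed from compound 1 to compound 4 (within the scatter).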

Compound 4, intrinsic clearance in microsomes: 1.8 mL.min-1.g-1
Beside the measured number, compound 4's estimate is 8.3-fold (0.92 log units) above it; measured number outside the range, below it.
By their numbers in this assay, from the lowest: compound 4; then compound 3; then compounds 2 and 1 (each within the scatter of the next).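

In this assay, the exchange of 4-bromophenyl for 2-bromophenyl gives an 8.3-fold lower number from compound 1 to compound 4 (0.92 log units; beyond the scatter), so on this core the place of the bromine on the phenyl ring alone shifts the read-out, with the same atoms present. No evidence shown accounts for this shift. The compounds shown leave open whether a group other than bromine, such as chlorine, an amine or a carboxylic acid, would give a similar shift. They also leave open whether the same exchange would have this effect on another core.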